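This account rests on a few compounds, and the source may have more. Where it says the series, first, only, none or still open, it means among the compounds named here.

Compound 1 `COc1cccc(C(=O)n2c(-c3cn(C)c4ccccc34)nc3ccccc32)c1`: 10200 nM
Compound 2 `COc1cccc(C(=O)n2c(-c3cn(C)c4ccc(OC)cc34)nc3ccccc32)c1`: 4600 nM
Compound 3 `COc1ccccc1C(=O)n1c(-c2cn(C)c3ccc(Br)cc23)nc2ccccc21`: 12800 nM

All three compounds were tested in a functional assay on A549 cells (Homo sapiens) for inhibition, read by MTT assay, with a stated time of 24 h; on this read-out lower numbers stand for stronger inhibition of growth and higher numbers for weaker inhibition of growth. Compound 3 stands at the high end of this small set. Its number and that of compound 1 lie within the usual scatter of each other, while compound 2 shows a clearly lower number than either.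

The next compound is compound 4 `COc1cccc(C(=O)n2c(-c3cn(C)c4ccc(Br)cc34)nc3ccccc32)c1`. It has 3-methoxyphenyl in place of 2-methoxyphenyl on a carbonyl carbon. The atoms stay the same and are only joined differently.

Within the data shown here, no measured step tests this swap directly. Among the measured compounds shown here, the one measured step, a 2.2-fold lower number from compound 1 to compound 2 (0.35 log units; beyond the scatter), is modest and comes from a change elsewhere in the molecule, methoxy in place of hydrogen on an aromatic carbon, so it bears only indirectly. More useful is that compound 4 shares its 3-methoxyphenyl group with two measured compounds: compound 1 gives 10200 nM and compound 2 gives 4600 nM. Neither number lies above that of compound 3, so a small step toward a lower number seems likely, perhaps none beyond the scatter.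

For compound 4 the expected value is 8000 nM, with an estimated range from 3500 nM to 18000 nM. This estimate means an expected 1.6-fold lower number from compound 3 to compound 4 (0.20 log units; within the scatter).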

Compound 4, concentration for 50% growth inhibition: 10800 nM
Estimate against measurement, compound 4: 1.4-fold (0.13 log units) below, and the stated range covers the measured number.
By their numbers in this assay, from the lowest: compound 2; then compounds 1, 4 and 3 (each within the scatter of the next).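

Within this assay, replacing 2-methoxyphenyl with 3-methoxyphenyl on the carbonyl carbon, while the bromo stays in place, gives a 1.2-fold lower number from compound 3 to compound 4 (0.07 log units; within the scatter) and so has no effect that can be told apart from ordinary assay variation in this one pair. Compound 4 also shows that the two substituents on the core do not count alike: bromo in place of hydrogen gives a 1.1-fold higher number from compound 1 to compound 4 (0.02 log units; within the scatter) and so cannot be distinguished from the unsubstituted compound, whereas bromo in place of methoxy gives a 2.3-fold higher number from compound 2 to compound 4 (0.37 log units; beyond the scatter) and brings a modest loss of growth inhibition, leaving the methoxy of compound 2 as the only one of these substituents that stands apart. No measurement shown here explains any of these steps.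

From the compounds shown here alone, the two methoxyphenyl groups are compared only in compounds that carry the bromo, so it remains open whether the same swap would matter in a compound carrying the methoxy on the core. Going by these compounds, it also remains open how the number would respond if an amine or a carboxylic acid took the place of the methoxy on the phenyl ring attached to the carbonyl carbon.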